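The source may report more compounds than this note shows. Statements on the series, on what has been measured and on what is new or still open speak of the compounds shown alone.

Compound 1 `O=C(CCCCCCc1nc(-c2ccc(F)cc2)no1)NO`: 19400 nM
Compound 2 `O=C(CCCCCCc1nc(-c2cccnc2)no1)NO`: 6020 nM
Compound 3 `Nc1ccccc1NC(=O)CCCCCCc1nc(-c2ccccc2)no1`: 960 nM

In a functional assay on NCI-H661 cells (Homo sapiens) for antiproliferative activity, read by MTT assay, with a stated time of 72 h (a lower number here means a stronger inhibitor, a higher number a weaker inhibitor), compound 3 gives the lowest of the three numbers at 960 nM, with compound 2 higher at 6020 nM and compound 1 higher still at 19400 nM. The next structure, compound 4 `Nc1ccccc1NC(=O)CCCCCCc1nc(-c2ccccc2Cl)no1`, departs from compound 3 in one place: chloro in place of hydrogen on an aromatic carbon. In words, this is chloro in place of hydrogen on an aromatic carbon, taking phenyl to 2-chlorophenyl.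

Among the measured compounds shown here, only one measured step concerns this aromatic group, a 3.2-fold lower number from compound 1 to compound 2 (0.51 log units; beyond the scatter). That step was modest, involved a different pair of groups, and was measured on compounds that also differ from compound 3 elsewhere in the structure. For the measured compounds named here, no measured step adds chloro, so the data offer a rough scale but no direction. A step no larger than that modest one is expected, quite possibly none beyond the scatter. The expected outcome is a 1.0-fold higher number from compound 3 to compound 4 (0.02 log units; within the scatter). For compound 4 the estimated value is 1000 nM, with an expected range from 350 nM to 3000 nM.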

Compound 4, half-maximal inhibitory concentration: 8310 nM
Compound 4: middle estimate off by 8.3-fold (0.92 log units), on the low side, and the stated range ends below it.
By their numbers in this assay, from the lowest: compound 3; then compounds 2 and 4 (each within the scatter of the next); then compound 1.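

Over an 8.7-fold higher number from compound 3 to compound 4 (0.94 log units; beyond the scatter) in this assay, a single chloro on an aromatic carbon, ortho to a large group, is enough to move the number well away from that of compound 3. Among the compounds shown here, the only earlier change to this aromatic group, a 3.2-fold lower number from compound 1 to compound 2 (0.51 log units; beyond the scatter), went towards a lower number, involved different groups and was measured on compounds that differ from compound 3 elsewhere; this step shows that the aromatic group can also move the number upwards, through one added heavy atom. Nothing measured here accounts for the change.

Going by these compounds, whether a fluoro or a methyl at the same place would shift the number as far remains open, as does the effect of chloro elsewhere on the ring. On these data alone, it is also open whether 2-chlorophenyl would act in the same way with the hydroxamic acid end of compound 1.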